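This account rests on a few compounds, and the source may have more. Where it says the series, first, only, none or still open, it means among the compounds named here.

In a functional assay on M14 cells (Homo sapiens) for inhibition, read by sulforhodamine B assay, with a stated time of 48 h (on this read-out lower numbers stand for stronger inhibition of growth and higher numbers for weaker inhibition of growth), compound 1 `O=C(Cc1csc2nc(-c3ccc(Br)cc3)cn12)N/N=C/c1ccccc1O` gives 2570 nM and compound 2 `O=C(Cc1csc2nc(-c3ccc(Br)cc3)cn12)N/N=C/c1ccc(O)cc1` gives 10200 nM as the higher of the two numbers. The change to compound 3 `COc1cccc(OC)c1/C=N/NC(=O)Cc1csc2nc(-c3ccc(Br)cc3)cn12` is 2,6-dimethoxyphenyl in place of 4-hydroxyphenyl on a carbon with a double bond to nitrogen with the core unchanged. Among the compounds with values here, only one measured step bears on this: a 4.0-fold higher number from compound 1 to compound 2 (0.60 log units; beyond the scatter) is a modest step between two hydroxyphenyl groups and involves no methoxy group, so the guidance is thin. A modest step toward a lower number is expected, namely a 2.0-fold lower number from compound 2 to compound 3 (0.31 log units; beyond the scatter) on the strength of that single comparison. For compound 3 the estimated value is 5000 nM with an expected range from 1800 nM to 14000 nM as a wide allowance.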

Compound 3, concentration for 50% growth inhibition: 15100 nM
For compound 3 the middle estimate is 3.0-fold (0.48 log units) below the measured one; measured number outside the range, above it.
By their numbers in this assay, from the lowest: compound 1; then compounds 2 and 3 (each within the scatter of the next).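

In this assay, 2,6-dimethoxyphenyl in place of 4-hydroxyphenyl on a carbon with a double bond to nitrogen gives a 1.5-fold higher number from compound 2 to compound 3 (0.17 log units; within the scatter) and so separates neither compound, even though the entering group has 0 hydrogen-bond donors. Set against 2-hydroxyphenyl, the same group gives a 5.9-fold higher number from compound 1 to compound 3 (0.77 log units; beyond the scatter) and leaves compound 1 apart from both others. No measurement on hand accounts for this.

Going by these compounds, whether an amine or a carboxylic acid at this place would match compound 1 stays open. So does whether a single methoxy group would track with 2,6-dimethoxyphenyl.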